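The source may hold more compounds than are shown below. What is called first, only, known or untested is meant among the compounds shown, and "the series" means these compounds.

Working notes on the series. In a functional assay on SW480 cells (Homo sapiens) for antiproliferative activity, read by MTT assay, with a stated time of 48 h (a higher number here means a weaker inhibitor, a lower number a stronger inhibitor), compound 1 `CC(=O)OC/C1=C/C[C@](C)(CCC=C(C)C)/C=C/[C@@H](OC(=O)C=C(C)C)[C@](C)(OC(C)=O)/C=C/C1=O` gives 3520 nM. Compound 2 `C=C1/C=C/C(=O)/C(CO)=C\C[C@](C)(CCC=C(C)C)/C=C/[C@H]1OC(=O)C=C(C)C` gives 2970 nM. Neither compound carries the carboxy group of compound 3 `CC(C)=CCC[C@]1(C)/C=C/[C@@H](OC(=O)C=C(C)C)[C@](C)(O)/C=C/C(=O)/C(C(=O)O)=C\C1`. Compound 3 gives > 10000 nM, which is a limit of the assay and not a number, and it is the only one of the three at that limit. Compound 4 `CC(C)=CCC[C@]1(C)/C=C/[C@@H](OC(=O)C=C(C)C)[C@](C)(O)/C=C/C(=O)/C(CN2CCCC2)=C\C1` differs from it by one change, (pyrrolidin-1-yl)methyl in place of carboxy on a double-bonded ring carbon. Within the data shown here, no measured pair isolates this change, so the expectation is tentative. A move toward stronger inhibition in this assay, beyond the scatter, is expected, an estimated at least 3.3-fold lower number from compound 3 to compound 4 (0.52 log units; beyond the scatter). For compound 4 the estimated value is 3000 nM, with an expected range of 900 nM to 9000 nM.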

Compound 4, half-maximal inhibitory concentration: 310 nM
For compound 4 the middle estimate is 9.7-fold (0.99 log units) above the measured one; the measured number lies below the stated range.
By their numbers in this assay, from the lowest: compound 4; then compounds 2 and 1 (each within the scatter of the next). At a limit, above all of these: compound 3.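

On this double-bonded ring carbon, (pyrrolidin-1-yl)methyl in place of carboxy gives an at least 32-fold lower number from compound 3 to compound 4 (1.50 log units; beyond the scatter) in this assay, so the group carried here strongly affects the read-out. Compound 3 gives > 10000 nM, which is a limit of the assay and not a number. The size of the step is therefore only a lower bound: the limit of > 10000 nM in this assay, at which 1 of the 4 values shown sits.

Going by these compounds, it remains open whether the pyrrolidine ring itself matters or whether a piperidine, a morpholine or an open-chain dimethylamine on the same methyl carbon would serve equally well. A carboxylic ester at this position is also untested among the compounds shown.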